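Inverting a Single Stereocentre in an Isopropyl-Substituted Urea

The source may report more compounds than this note shows. Statements on the series, on what has been measured and on what is new or still open speak of the compounds shown alone.

Three ureas have been measured in an ADME assay on the whole organism with Oryza sativa as the target, tested at 10 uM; a higher number here means a weaker effect of the compound at the concentration tested, a lower number a stronger effect. Compound 1 `Cc1ccc(NC(=O)N[C@@H](C)c2ccccc2)cc1` gives 100%, compound 2 `CCc1ccc(NC(=O)N[C@@H](C)c2ccccc2)cc1` gives 91%, and compound 3 `CC(C)c1ccc(NC(=O)N[C@H](C)c2ccccc2)cc1` gives 49%, the lowest of the three, its nearest neighbour being compound 2 and its furthest compound 1, both separated from it by more than the scatter. Compound 4 `CC(C)c1ccc(NC(=O)N[C@@H](C)c2ccccc2)cc1` differs from compound 3 as follows: the two compounds have the same atoms and bonds and differ only in configuration as drawn: 1 of 1 stereo elements differ; a stereocentre at a saturated chain carbon is drawn R in compound 3 and S in compound 4. Among the compounds with values here, the only step measured so far, a number 9 percentage points lower from compound 1 to compound 2 (within the scatter), concerns a chain substituent rather than configuration, so no step bears on this change. The author therefore expects an uncertain, probably upward step a number 21 percentage points higher from compound 3 to compound 4 (beyond the scatter) in this assay, and estimates for compound 4 a value of 70%, between 40% and 100%.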

Compound 4, a percentage reported as activity, at one concentration (the size of the read-out at that concentration, not a potency): 86%
Compound 4: the middle estimate sits 16 percentage points below what was measured, within the range that was stated.
By their numbers in this assay, from the lowest: compound 3; then compounds 4, 2 and 1 (each within the scatter of the next, the first and the last beyond it).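

In this assay, a stereocentre at a saturated chain carbon drawn S rather than R gives a number 37 percentage points higher from compound 3 to compound 4 (beyond the scatter), and this step can be laid on configuration alone because of one fact: the fact that compounds 3 and 4 differ only in the configuration as drawn

Among the compounds sharing that S drawing, isopropyl in place of methyl on an aromatic carbon gives a number 14 percentage points lower from compound 1 to compound 4 (beyond the scatter), while methyl in place of hydrogen on the saturated chain carbon of the ethyl group gives a number 5 percentage points lower from compound 2 to compound 4 (within the scatter).

On these data alone, only the isopropyl pair shows both configurations, so whether inversion acts likewise with methyl or ethyl stays open. As far as these compounds go, how a tert-butyl group or a carboxylic acid on that aromatic carbon would read is also open.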